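This account rests on a few compounds, and the source may have more. Where it says the series, first, only, none or still open, it means among the compounds named here.

Going by the values given here, in a functional assay on RS4-11 cells (Homo sapiens) for inhibition, read by CCK-8 assay, with a stated time of 48 h, tested at 20 uM (a lower number here means less inhibition of growth, a higher number more inhibition of growth at the concentration tested), compound 2 (`Cc1ccc(S(=O)(=O)Oc2cccc(/C=C(\C#N)C(=O)Nc3nnc(-c4cccs4)s3)c2)cc1`) gives 25% and so holds the lower of the two numbers known so far, with compound 1 (`COc1ccc(-c2nnc(NC(=O)/C(C#N)=C/c3cccc(OS(=O)(=O)c4ccc(C)cc4)c3)s2)cc1`) at 79% on the higher side. Compound 3 (`N#C/C(=C\c1cccc(OS(=O)(=O)c2cccs2)c1)C(=O)Nc1nnc(-c2cccs2)s1`) departs from compound 2 in one place (thiophen-2-yl in place of 4-methylphenyl on a sulfonyl sulfur) with thiophen-2-yl in place of 4-methylphenyl on a sulfonyl sulfur.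

Among the compounds with values here, only one measured step bears on this change. The step of a number 54 percentage points lower from compound 1 to compound 2 (beyond the scatter) is large and beyond the scatter, and it also brought in thiophen-2-yl, there in place of 4-methoxyphenyl. That swap took place on an aromatic carbon, however, not on a sulfonyl sulfur, so it is only a loose guide. Within the data shown here, no measurement yet covers a change at the sulfonyl sulfur. Compound 2 at 25% also leaves limited room to fall on this scale. A small fall in this assay is expected, and none beyond the scatter. The expected change is a number 5 percentage points lower from compound 2 to compound 3 (within the scatter) in this estimate. For compound 3 the estimated value is 20% with an expected range of 5% to 40% as the likely span.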

Compound 3, percent growth inhibition at one concentration: "not active" (no number reported)
Compound 3: no number reported, and the estimate cannot be compared.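

Going by these compounds alone, compound 3 is reported only as "not active", without a number, so no step from compound 2 to compound 3 can be read. The compounds shown leave open how far thiophen-2-yl in place of 4-methylphenyl on a sulfonyl sulfur shifts growth inhibition on its own. Nothing measured here accounts for this result.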